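The compounds below may be only part of what the source reports. "The series", "measured", "known", "first", "only" and "open" are said of these compounds alone.

Working notes on the series. In a functional assay on Vero cells (Chlorocebus sabaeus) for inhibition (on this read-out lower numbers stand for stronger inhibition and higher numbers for weaker inhibition), compound 1 `Nc1nc(O)c2ncn([C@@H]3O[C@@H](CO)C=C3F)c2n1` gives > 100000 nM, which is a limit and not a number. Compound 2 `OC[C@H]1C=C(F)[C@H](n2cnc3c(O)ncnc32)O1` gives > 100000 nM in this assay, again a limit. Compound 3 `Nc1nc(F)nc2c1ncn2[C@@H]1O[C@@H](CO)C=C1F` gives > 100000 nM, also a limit. Compound 1 therefore has no number of its own, and its only standing is the limit of > 100000 nM in this assay, at which 3 of the 3 values shown sit.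

Compound 4 `Nc1nc(O)c2ncn([C@H]3O[C@@H](CO)C=C3F)c2n1` has not yet been measured. Against compound 1 it shows the two compounds have the same atoms and bonds and differ only in configuration as drawn: 1 of 2 stereo elements differ; a stereocentre at a saturated ring carbon is drawn R in compound 1 and S in compound 4: a stereocentre at a saturated ring carbon is drawn R in compound 1 and S in compound 4.

For the measured compounds named here, the only measured step is a step that the two limits leave unreadable from compound 1 to compound 2, with hydrogen in place of amino on an aromatic carbon. Going by the values given here, it gives no size to carry over, and no measured step changes configuration. No step beyond the scatter is therefore expected in this assay, though the data set no firm bound on a change of configuration. This expectation rests on compound 1 at > 100000 nM, a limit. The expected change is a number no higher from compound 1 to compound 4 (the limit leaves the size open). Compound 4 is estimated at 100000 nM, with an expected range of 30000 nM to 200000 nM.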

Compound 4, half-maximal inhibitory concentration: > 100000 nM
Compound 4 was reported as a limit; the forecaster's own chance of this, stated with the estimate: 85%; the middle value lies on the limit itself.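

No step can be read from compound 1 to compound 4, as both stand only as limits in this assay: the limit of > 100000 nM in this assay, at which 4 of the 4 values shown sit. The compounds shown leave open whether the configuration at the saturated ring carbon, or any other change in the series, alters inhibition in this assay.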